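Removing One Methyl from Compound 2

The compounds below may be only part of what the source reports. "The series", "measured", "known", "first", "only" and "open" are said of these compounds alone.

Among the measured compounds shown here, compound 2 `COc1cc(Cl)cc(-c2nn(-c3cccc(NC(=O)Nc4ccc(Cl)c(C(F)(F)F)c4)c3)cc2-c2ccncc2)c1` is one of three compounds measured in a functional assay on KM12 cells (Homo sapiens) for inhibition, read by sulforhodamine B assay, with a stated time of 48 h, tested at 100 uM; a lower number here means a stronger effect, a higher number a weaker effect of the compound at the concentration tested. In this assay compound 2 gives -70%, the lowest of the three numbers. Compound 1 `COc1cc(Cl)cc(-c2nn(-c3cccc(NC(=O)Nc4cccc(C(F)(F)F)c4)c3)cc2-c2ccncc2)c1` gives -48%, and the step of a number 22 percentage points lower from compound 1 to compound 2 (beyond the scatter) lies beyond the scatter. Compound 3 `COc1cc(Cl)cc(-c2nn(-c3cccc(NC(=O)c4cccc(C(F)(F)F)c4)c3)cc2-c2ccncc2)c1` gives 28%; the step of a number 98 percentage points higher from compound 2 to compound 3 (beyond the scatter) is the widest gap seen, and a number 76 percentage points higher from compound 1 to compound 3 (beyond the scatter) points the same way.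

Compound 4 `O=C(Nc1cccc(-n2cc(-c3ccncc3)c(-c3cc(O)cc(Cl)c3)n2)c1)Nc1ccc(Cl)c(C(F)(F)F)c1` differs from compound 2 in a single place: hydrogen in place of methyl on an oxygen on an aromatic ring, that is, methoxy to hydroxy. For the measured compounds named here, none of the measured steps touches this oxygen; all of them alter what sits on the carbonyl carbon at the other end of the shared core. So no measured step bears on the step from compound 2 to compound 4, and its size cannot be read from the numbers so far. With nothing pointing either way, the step of a number 8 percentage points higher from compound 2 to compound 4 (within the scatter) is expected to stay within the scatter. Compound 4 is therefore estimated at -62%, within a range from -95% to -20%.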

Compound 4, a percentage reported as activity, at one concentration (the size of the read-out at that concentration, not a potency): -74%
Compound 4: middle estimate off by 12 percentage points, on the high side; measured number inside the range.
By their numbers in this assay, from the lowest: compounds 4 and 2 (each within the scatter of the next); then compound 1; then compound 3.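

Among the compounds shown here, until now, every measured step altered what sits on the carbonyl carbon; compound 4 is the first to change the 3-chloro-5-methoxyphenyl group at the other end of the shared core. In this assay, the step of a number 4 percentage points lower from compound 2 to compound 4 (within the scatter) means that methoxy and hydroxy cannot be told apart here, so this methyl can be removed without a change beyond the scatter, whereas the step of a number 98 percentage points higher from compound 2 to compound 3 (beyond the scatter) at the carbonyl carbon is far larger. Nothing available explains why this exchange on the oxygen gives such a result.

From the compounds shown here alone, it remains open whether a longer chain on this oxygen, such as ethoxy, or an amine in its place would also match compound 2. Going by these compounds, because each number is the size of the read-out at a single concentration, any difference in potency between these two compounds also remains unknown.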